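Side-chain variation on the shared core

The source may hold more compounds than are shown below. What is called first, only, known or untested is meant among the compounds shown, and "the series" means these compounds.

Compound 2 `OCCCCCNc1nnc(-c2ccc(F)c(F)c2Nc2ccc(I)cc2F)o1` gives 0.667 h in an in vitro ADME assay on microsomes from liver (Homo sapiens) for metabolic stability; a lower number here means that the compound disappears faster, a higher number that the compound lasts longer. Compound 1 `CCN(CC)CCCNc1nnc(-c2ccc(F)c(F)c2Nc2ccc(I)cc2F)o1` gives 0.667 h, so the two stand at the same number, and compound 3 `COCCCNc1nnc(-c2ccc(F)c(F)c2Nc2ccc(I)cc2F)o1` gives 0.583 h, with the step of a 1.1-fold lower number from compound 2 to compound 3 (0.06 log units; within the scatter) inside the scatter. Compound 4 `NCCNc1nnc(-c2ccc(F)c(F)c2Nc2ccc(I)cc2F)o1` differs from compound 2 in one place: amino in place of 3-hydroxypropyl on a saturated chain carbon, two bonds along the chain from a nitrogen on an aromatic ring. The measured steps that bear on this change, no change at the digits printed from compound 1 to compound 2 (within the scatter), a 1.1-fold lower number from compound 1 to compound 3 (0.06 log units; within the scatter) and a 1.1-fold lower number from compound 2 to compound 3 (0.06 log units; within the scatter), are all exchanges on the saturated chain and all lie within the scatter. For this assay, no step beyond the scatter is therefore expected, and the estimate for compound 4 means a 1.0-fold lower number from compound 2 to compound 4 (0.01 log units; within the scatter). Compound 4 is estimated at 0.65 h, with a range from 0.35 h to 1.2 h.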

Compound 4, half-life: 0.667 h
The estimate for compound 4 lay 1.0-fold (0.01 log units) below the measured number; measured number inside the range.
By their numbers in this assay, from the lowest: compounds 3, 1, 2 and 4 (each within the scatter of the next).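

In this assay, the amino-ended chain of compound 4 stays level with the other side chains: no change at the digits printed from compound 2 to compound 4 (within the scatter), no change at the digits printed from compound 1 to compound 4 (within the scatter) and a 1.1-fold higher number from compound 3 to compound 4 (0.06 log units; within the scatter). At this place, amino in place of 3-hydroxypropyl therefore gives no step beyond the scatter, and an amino end joins the diethylamino, hydroxyl and methoxy ends with none among them. Nothing available explains this flat read-out across the chains.

With all four compounds within the scatter of one another, none shows which change at this position could move the half-life. On these data alone, whether a carboxylic acid or a morpholine ring at the chain end would step beyond the scatter remains open.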